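The source may hold more compounds than are shown below. What is called first, only, known or untested is meant among the compounds shown, and "the series" means these compounds.

Measured so far:
compound 1 `O=c1nc(-c2ccccc2)c2cc(-c3ccccc3F)ccc2[nH]1`: 50000 nM
compound 2 `CNC(=O)c1cccc(-c2ccc3[nH]c(=O)nc(-c4ccccc4)c3c2)c1`: > 50000 nM

Among the measured compounds shown here, in an ADME assay on THP-1 cells (Homo sapiens) for cytotoxicity, read by MTT assay, with a stated time of 72 h (a higher number here means that more compound is needed for the effect, a lower number that less compound is needed), compound 1 gives 50000 nM, the only actual number. Compound 2 gives > 50000 nM, which is a limit of the assay and not a number. The standing of compound 1 therefore cannot be ranked against a second number.

Compound 3 `O=c1nc(-c2ccccc2)c2cc(-c3cc[nH]n3)ccc2[nH]1` is the next to be read, with 1H-pyrazol-3-yl in place of 2-fluorophenyl on an aromatic carbon. For the measured compounds named here, no measured step sizes this change. The expectation therefore rests on compound 1 at 50000 nM, with no step beyond the scatter in this assay and no favoured direction. The expected change is no change at the digits printed from compound 1 to compound 3 (within the scatter). A report of only a limit is also expected to be quite possible. For compound 3 the estimated value is 50000 nM, with an expected range of 25000 nM to 100000 nM.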

Compound 3, half-maximal effective concentration: > 50000 nM
Compound 3: no number, only a limit; the forecaster's own chance of this, stated with the estimate: 60%; the middle value lies on the limit itself.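

In this assay, 1H-pyrazol-3-yl in place of 2-fluorophenyl on this aromatic carbon gives a number no lower from compound 1 to compound 3 (the limit leaves the size open). Compound 3 gives > 50000 nM, which is a limit of the assay and not a number. This position therefore takes a five-membered aromatic ring with 2 hetero atoms in place of a six-membered aromatic ring of carbon only, with no lower number than that of compound 1 appearing, and the readings in the series now cluster at a single limit: the limit of > 50000 nM in this assay, at which 2 of the 3 values shown sit.

As far as these compounds go, whether an amine, a carboxylic acid or a longer chain on this aromatic carbon would give a number rather than a limit stays open. From the compounds shown here alone, the true size of the step also stays open, as does any gap in cytotoxicity among the compounds that reach the limit.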